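This account rests on a few compounds, and the source may have more. Where it says the series, first, only, none or still open, it means among the compounds named here.

Compound 2 `Cc1cc(Nc2ccccc2)c(S(C)(=O)=O)cc1C(=O)N=C(N)N` gives 21 nM in a functional assay for inhibition of sodium/hydrogen exchanger (Oryctolagus cuniculus); a lower number here means a stronger inhibitor, a higher number a weaker inhibitor; compound 1 `CCC(C)c1cc(C)c(C(=O)N=C(N)N)cc1S(C)(=O)=O` gives 8 nM, so compound 2 has the higher number of the two, by a 2.6-fold higher number from compound 1 to compound 2 (0.42 log units; beyond the scatter). Compound 3 `Cc1cc(-n2ccc(=O)cc2)c(S(C)(=O)=O)cc1C(=O)N=C(N)N` differs from compound 2 in one place: a group of 7 heavy atoms (5 carbon, 1 nitrogen, 1 oxygen; one six-membered aromatic ring with 1 hetero atom) in place of a group of 7 heavy atoms (6 carbon, 1 nitrogen; one six-membered aromatic ring of carbon only), on an aromatic carbon, on an aromatic carbon ortho to a methylsulfonyl group. Among the measured compounds shown here, no measured step tries this exchange; the only step known, from sec-butyl to anilino, was modest. Compound 3 is therefore expected to shift only slightly, by a 1.7-fold higher number from compound 2 to compound 3 (0.22 log units; within the scatter), toward a weaker inhibitor. The estimate for compound 3 is 35 nM, within 12 nM to 120 nM.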

Compound 3, half-maximal inhibitory concentration: 75 nM
For compound 3 the middle estimate is 2.1-fold (0.33 log units) below the measured one; the measured number falls inside the stated range.
By their numbers in this assay, from the lowest: compound 1; then compound 2; then compound 3.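

At this carbon, ortho to a methylsulfonyl group, exchanging anilino for the oxygen-bearing aromatic ring gives a 3.6-fold higher number from compound 2 to compound 3 (0.55 log units; beyond the scatter), a larger step than the first one, and sec-butyl to that ring gives a 9.4-fold higher number from compound 1 to compound 3 (0.97 log units; beyond the scatter). Anilino and the entering group hold the same count of heavy atoms, so that count alone does not set the number here. No evidence on hand explains the shift. On these data alone, whether a simple amine or a piperidine ring at this carbon would lie nearer compound 1 or compound 3 stays open.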